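The source may hold more compounds than are shown below. What is called first, only, known or untested is meant among the compounds shown, and "the series" means these compounds.

Working notes on the series.

For the measured compounds named here, compound 2 `COc1cc2nnc(C(N)=O)c(Nc3ccc(C)cc3F)c2cc1N1C[C@@H](C)N[C@@H](C)C1` gives the higher of the two numbers so far in a physicochemical assay for solubility; a higher number here means a more soluble compound, a lower number a less soluble compound. Going by the values given here, compound 2 gives 200000 nM, and compound 1 `COc1cc2nnc(C(N)=O)c(Nc3ccc(C)cc3F)c2cc1N1CCCN(C)CC1` gives 54000 nM, so compound 2 stands above its only neighbour by a 3.7-fold higher number from compound 1 to compound 2 (0.57 log units; beyond the scatter).

Compound 3 `COc1cc2nnc(C(N)=O)c(Nc3ccc(C)cc3F)c2cc1N1CCC(N(C)C)CC1` is the next member and has yet to be measured in this assay. Its change from compound 2 is 4-(dimethylamino)piperidin-1-yl in place of 3,5-dimethylpiperazin-1-yl on an aromatic carbon. Among the compounds with values here, only one measured step bears on this position of the shared core, the step of a 3.7-fold higher number from compound 1 to compound 2 (0.57 log units; beyond the scatter), which is modest and which ran from a ring carrying a tertiary amine and no hydrogen-bond donor to one carrying a secondary amine as donor. Compound 3 returns to a ring carrying a tertiary amine and no donor, so a reversal of part of that step seems the likelier outcome, with the expected step from compound 2 to compound 3 being a 2.0-fold lower number from compound 2 to compound 3 (0.30 log units; within the scatter), a modest decrease that may fall close to the usual scatter.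

Compound 3 is therefore expected to come in at about 100000 nM in this assay, with a range of 35000 nM to 300000 nM.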

Compound 3, solubility: 340000 nM
The estimate for compound 3 lay 3.4-fold (0.53 log units) below the measured number, and the stated range ends below it.
By their numbers in this assay, from the lowest: compound 1; then compounds 2 and 3 (each within the scatter of the next).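

In this assay, 4-(dimethylamino)piperidin-1-yl in place of 3,5-dimethylpiperazin-1-yl on the aromatic carbon ortho to the methoxy group gives a 1.7-fold higher number from compound 2 to compound 3 (0.23 log units; within the scatter), so compound 2 and compound 3 stand level, and a hydrogen-bond donor on this group is not needed to reach a number of this size. Hydrogen-bond donors alone also do not sort the three compounds: neither compound 1 nor compound 3 carries one on this group, yet the change between their groups gives a 6.3-fold higher number from compound 1 to compound 3 (0.80 log units; beyond the scatter), the widest gap so far at this position. No measurement offered here accounts for either step.

Going by these compounds, it remains open how a morpholine, with an oxygen in the ring in place of the second nitrogen, or an open-chain amine such as a dimethylaminoethyl chain, would read at this carbon. All three compounds share the rest of the core, so whether these steps would hold with a different group elsewhere on it cannot be told from them.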